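A few compounds are considered here, and "the series" means these few. Any claim that something is new, unique, unknown or untested is made for them only; others in the source may bear on it.

Measured compounds, with their solubility in a physicochemical assay for solubility, in phosphate buffer, measured as kinetic solubility; a lower number here means a less soluble compound, a higher number a more soluble compound:
- compound 1 `CC(C)NC(=O)CC(c1ccc(-c2ccc3cccc(F)c3c2)[nH]c1=O)C(C)C`: 18000 nM
- compound 2 `CC(C)C(Cc1ncc[nH]1)c1ccc(-c2ccc3cccc(F)c3c2)[nH]c1=O`: 22100 nM
- compound 3 `CC(C)C(/C=C1\CCNC1=O)c1ccc(-c2ccc3cccc(F)c3c2)[nH]c1=O`: 20700 nM

All three share a core and differ only in the group attached on a saturated chain carbon bound to an aromatic carbon and a saturated chain carbon. Compound 3 stands second highest of the three numbers, but its neighbours are close: a 1.1-fold lower number from compound 2 to compound 3 (0.03 log units; within the scatter) and a 1.2-fold higher number from compound 1 to compound 3 (0.06 log units; within the scatter) both fall inside the scatter, so the three values cannot be told apart.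

Compound 4 `CC(C)C(c1noc(=O)[nH]1)c1ccc(-c2ccc3cccc(F)c3c2)[nH]c1=O` is the next variant at the same position. The change is a group of 6 heavy atoms (2 carbon, 2 nitrogen, 2 oxygen; one five-membered aromatic ring with 3 hetero atoms) in place of a group of 7 heavy atoms (5 carbon, 1 nitrogen, 1 oxygen; one five-membered non-aromatic ring with 1 hetero atom), on a saturated chain carbon bound to an aromatic carbon and a saturated chain carbon

Going by the values given here, the steps that bear on this are the two earlier swaps at this spot, a 1.2-fold higher number from compound 1 to compound 2 (0.09 log units; within the scatter) and a 1.2-fold higher number from compound 1 to compound 3 (0.06 log units; within the scatter), neither of which moved the number beyond the scatter. Groups of quite different shape have been exchanged there without a measurable effect, so the expectation for compound 4 is again no step beyond the scatter, a 1.0-fold higher number from compound 3 to compound 4 (0.01 log units; within the scatter). Compound 4 is therefore estimated at 21000 nM, with a range from 10000 nM to 45000 nM.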

Compound 4, solubility: 32500 nM
Estimate against measurement, compound 4: 1.5-fold (0.19 log units) below, within the range that was stated.
By their numbers in this assay, from the lowest: compounds 1, 3, 2 and 4 (each within the scatter of the next).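

Going by these compounds alone, compound 4 carries the first group here with two oxygens and a five-membered aromatic ring with 3 hetero atoms, yet in this assay the comparison with each earlier compound stays inside the scatter: a 1.6-fold higher number from compound 3 to compound 4 (0.20 log units; within the scatter), a 1.5-fold higher number from compound 2 to compound 4 (0.17 log units; within the scatter) and a 1.8-fold higher number from compound 1 to compound 4 (0.26 log units; within the scatter). The tolerance seen among compounds 1, 2 and 3 therefore extends to a group with a different set of atoms, so all four compounds remain indistinguishable in this read-out. Nothing measured alongside these values offers an explanation for them.

Still open, on these data alone, is whether an amine, a carboxylic acid or a longer chain on this saturated chain carbon would give a step beyond the scatter. These four compounds also cannot show whether the same swaps would behave alike on a different core.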